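The compounds below may be only part of what the source reports. "The series", "measured", "known", "first", "only" and "open" are said of these compounds alone.

Measured compounds:
- Compound 1, `COc1ccccc1-c1cc(C2CCNC2)ccc1Cl`: 29%
- Compound 2, `COc1ccccc1-c1cc(C2CCN(C)C2)ccc1Cl`: 9.8%
- Compound 3, `CCNCc1ccc(Cl)c(-c2ccccc2OC)c1`: 71%

In a functional assay on HEK293 cells for agonist activity at 5-hydroxytryptamine receptor 7 (Homo sapiens), read by cAMP accumulation, with a stated time of 30 min (a lower number here means a smaller maximal response, a higher number a larger maximal response), compound 3 gives the highest of the three numbers, 71%. Its nearest neighbour is compound 1 with 29%, and the furthest is compound 2 with 9.8%; both gaps lie beyond the scatter, as shown by a number 42 percentage points higher from compound 1 to compound 3 (beyond the scatter) and a number 61.2 percentage points higher from compound 2 to compound 3 (beyond the scatter).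

Compound 4, `CCCCNCc1ccc(Cl)c(-c2ccccc2OC)c1`, differs from compound 3 in one place: ethyl in place of hydrogen on a saturated chain carbon, two bonds along the chain from an amine nitrogen.

Going by the values given here, none of the measured steps touches this position. The two steps leading to compound 3 concern the exchange of the ring-bound amine for the (ethylamino)methyl group, and a number 19.2 percentage points lower from compound 1 to compound 2 (beyond the scatter) concerns a methyl on the ring nitrogen of compound 1, where a small addition of carbon near the amine lowered the response. Among the compounds with values here, the account therefore has no direct precedent for lengthening the chain on the amine of compound 3, and the only related step hints that adding carbon around the nitrogen may cost some maximal response in this assay.

On that basis a modest downward step, a number 11 percentage points lower from compound 3 to compound 4 (beyond the scatter), is expected, with a range wide enough to include no change beyond the scatter. Compound 4 is estimated at 60%, between 35% and 85%.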

Compound 4, largest response reached (Emax), in percent of the reference or control that the assay uses: "not active" (no number reported)
For compound 4 the study gives words and no number; there is nothing to compare the estimate with.
By their numbers in this assay, from the lowest: compound 2; then compound 1; then compound 3.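

In this assay, going by these compounds alone, compound 4 is reported only in words, as not active, so no step from compound 3 to compound 4 can be read. Nothing measured here bears on that result. The compounds shown leave open how the maximal response of compound 3 varies with the length of the chain on its amine.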